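Shortening the amine chain from hexyl to allyl

This account rests on a few compounds, and the source may have more. Where it says the series, first, only, none or still open, it means among the compounds named here.

Among the compounds with values here, compound 2 `CCCCCCN1CCCC[C@H]1[C@H]1COC(c2ccccc2)(c2ccccc2)O1` gives 21200 nM in a functional assay (brain) for displacement of a labelled ligand, with Rattus norvegicus as the target (on this read-out higher numbers stand for weaker inhibition and lower numbers for stronger inhibition), the higher of the two numbers measured so far. Compound 1 `CCCN1CCCC[C@H]1[C@H]1COC(c2ccccc2)(c2ccccc2)O1` gives 6800 nM in this assay. Within the data shown here, the only measured step, a 3.1-fold higher number from compound 1 to compound 2 (0.49 log units; beyond the scatter), went with lengthening the chain, and the change to compound 3 `C=CCN1CCCC[C@H]1[C@H]1COC(c2ccccc2)(c2ccccc2)O1` runs the other way: vinyl in place of pentyl on a saturated chain carbon bound to an amine nitrogen in a ring. Because compound 1 sits at 6800 nM with a chain nearer in length to that of compound 3, compound 3 is expected to roughly reverse that step. The estimate for compound 3 is 6500 nM, with a range from 2500 nM to 17000 nM, an expected step of a 3.3-fold lower number from compound 2 to compound 3 (0.51 log units; beyond the scatter).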

Compound 3, inhibition constant: 15200 nM
For compound 3 the middle estimate is 2.3-fold (0.37 log units) below the measured one; measured number inside the range.
By their numbers in this assay, from the lowest: compound 1; then compounds 3 and 2 (each within the scatter of the next).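

In this assay hexyl to allyl at this position gives a 1.4-fold lower number from compound 2 to compound 3 (0.14 log units; within the scatter) and so does not separate compound 3 from compound 2. Vinyl in place of ethyl gives a 2.2-fold higher number from compound 1 to compound 3 (0.35 log units; beyond the scatter) and leaves compound 1 with the lowest number of the three, so a shorter chain alone does not bring the number down. Nothing at hand explains this difference.

Still open, on these data alone, is how a benzyl or a cyclopropylmethyl group would read at this position. Also open, as far as these compounds go, is whether a hydrogen on the amine nitrogen would give a lower number than compound 1.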